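Swapping 3-chlorophenyl for benzyl on a urea

This account rests on a few compounds, and the source may have more. Where it says the series, first, only, none or still open, it means among the compounds named here.

Compound 1 `CC1(C)CC(NC(=O)Nc2cccc(Cl)c2)c2cc(Br)ccc2O1` gives 69000 nM
Compound 2 `O=[N+]([O-])c1ccc(NC(=S)NCc2cccc(Cl)c2)cc1` gives 27000 nM

In a functional assay on U-373MG ATCC cells (Homo sapiens) for inhibition, read by MTT assay, with a stated time of 72 h (on this read-out lower numbers stand for stronger inhibition and higher numbers for weaker inhibition), compound 1 has the higher of the two numbers, and compound 2 lies lower by a gap beyond the usual scatter. The unmeasured compound 3 `CC1(C)CC(NC(=O)NCc2ccccc2)c2cc(Br)ccc2O1` carries benzyl in place of 3-chlorophenyl on an amide-type nitrogen. Within the data shown here, no measured pair shows this change, so the expectation is a loose one. The estimated step is a 1.2-fold lower number from compound 1 to compound 3 (0.06 log units; within the scatter), which is expected to stay within the scatter of this assay, with no clear direction. Compound 3 is expected at 60000 nM, with an estimated range of 25000 nM to 140000 nM.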

Compound 3, half-maximal inhibitory concentration: 27000 nM
Estimate against measurement, compound 3: 2.2-fold (0.35 log units) above; the range from low to high includes it.
By their numbers in this assay, from the lowest: compounds 2 and 3 (each within the scatter of the next); then compound 1.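

In this assay, this position on the urea proves sensitive to its substituent: benzyl in place of 3-chlorophenyl on the amide-type nitrogen gives a 2.6-fold lower number from compound 1 to compound 3 (0.41 log units; beyond the scatter), a modest step beyond the scatter. The swap removes the chlorine and adds a carbon, so this single pair cannot show which of the two matters. Nothing measured here explains the step. Unsubstituted phenyl on this nitrogen would help separate the two parts of the change. As far as these compounds go, how a longer chain, such as 2-phenylethyl, would behave also stays open.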